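The source may report more compounds than this note shows. Statements on the series, on what has been measured and on what is new or still open speak of the compounds shown alone.

Compound 2 `Nc1ccc(C(=O)/C=C/c2ccc3c(c2)B(O)OC3)cc1` gives 26100 nM in a functional assay on HCT-116 cells (Homo sapiens) for cytotoxicity, read by MTT assay, with a stated time of 48 h (on this read-out lower numbers stand for stronger inhibition and higher numbers for weaker inhibition), and stands at the highest of the two numbers recorded. Its nearest neighbour is compound 1 `O=C(/C=C/c1ccc2c(c1)B(O)OC2)c1ccc(Br)cc1`, which in this assay gives 9900 nM. For the measured compounds named here, the one recorded step, a 2.6-fold higher number from compound 1 to compound 2 (0.42 log units; beyond the scatter), exchanges bromo for amino on an aromatic carbon.

Compound 3 `O=C(/C=C/c1ccc2c(c1)B(O)OC2)c1ccc([N+](=O)[O-])cc1` is not yet measured; it differs from compound 2 by nitro in place of amino on an aromatic carbon. Going by the values given here, no measured step exchanges amino for nitro, so the only step that bears on this change is a 2.6-fold higher number from compound 1 to compound 2 (0.42 log units; beyond the scatter), a modest move. Among the compounds with values here, the only other group tested at this place, bromo in compound 1, gave the lower number, and nitro is untested against either group. A downward step of modest size, back toward the range of compound 1, is expected rather than none. Compound 3 is therefore estimated at 12000 nM, within 5000 nM to 30000 nM. The expected step is a 2.2-fold lower number from compound 2 to compound 3 (0.34 log units; beyond the scatter).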

Compound 3, half-maximal inhibitory concentration: 9100 nM
Beside the measured number, compound 3's estimate is 1.3-fold (0.12 log units) above it; low and high end bracket the measured number.
By their numbers in this assay, from the lowest: compounds 3 and 1 (each within the scatter of the next); then compound 2.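

In this assay, the place on an aromatic carbon para to a large group now has three groups, and nitro in place of amino gives a lower number (a 2.9-fold lower number from compound 2 to compound 3 (0.46 log units; beyond the scatter)). Nitro and bromo cannot be told apart here (a 1.1-fold lower number from compound 1 to compound 3 (0.04 log units; within the scatter)), so among these three compounds, compound 2 with its amino group stands alone at the higher number, with its steps to both others beyond the scatter. No measurement of any property accompanies these numbers, so the difference between amino and the other two groups stays unexplained.

Open, going by these compounds, is whether a methoxy group, a carboxylic acid or a dimethylamino group at this place would fall with amino or with nitro and bromo. Also open, on these data alone, is whether this grouping holds on any other read-out.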